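The source may report more compounds than this note shows. Statements on the series, on what has been measured and on what is new or still open speak of the compounds shown alone.

Three ureas sharing one core have been measured in an assay on isolated protein for activation of Nicotinamide phosphoribosyltransferase (Homo sapiens); on this read-out higher numbers stand for an effect only at larger amounts of compound and lower numbers for an effect already at smaller amounts. Compound 1 `O=C(NCc1ccncc1)Nc1ccc(S(=O)(=O)c2ccccc2Cl)cc1` gives 79 nM, compound 2 `O=C(NCc1ccncc1)Nc1ccc(S(=O)(=O)NCc2ccccc2)cc1` gives 102 nM, and compound 3 `CN(C1CCCC1)S(=O)(=O)c1ccc(NC(=O)NCc2ccncc2)cc1` gives 123 nM. Compound 3 thus has the highest of the three numbers, yet its distance to the others is small: a 1.2-fold higher number from compound 2 to compound 3 (0.08 log units; within the scatter) and a 1.6-fold higher number from compound 1 to compound 3 (0.19 log units; within the scatter), both within the scatter, so no order among the three can be read from these values.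

Compound 4 `CN(C)S(=O)(=O)c1ccc(NC(=O)NCc2ccncc2)cc1` is the next compound to be measured. It differs from compound 3 by methyl in place of cyclopentyl on a sulfonamide nitrogen, a change that makes the group on the sulfonyl sulfur smaller.

All three measured steps concern the group on the sulfonyl sulfur, and each stayed within the scatter: a 1.3-fold higher number from compound 1 to compound 2 (0.11 log units; within the scatter), a 1.6-fold higher number from compound 1 to compound 3 (0.19 log units; within the scatter), a 1.2-fold higher number from compound 2 to compound 3 (0.08 log units; within the scatter). On this basis, changing that group once more is expected to move this assay by no more than the scatter, so for compound 4 the step of a 1.2-fold higher number from compound 3 to compound 4 (0.09 log units; within the scatter) is expected. The estimated value for compound 4 is 150 nM, with a range from 70 nM to 320 nM.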

Compound 4, half-maximal effective concentration: 3110 nM
Compound 4: middle estimate off by 21-fold (1.32 log units), on the low side; the measured number lies above the stated range.
By their numbers in this assay, from the lowest: compounds 1, 2 and 3 (each within the scatter of the next); then compound 4.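

Until now, every change to the group on the sulfonyl sulfur stayed within the scatter, but this position does respond: methyl in place of cyclopentyl on a sulfonamide nitrogen gives a 25-fold higher number from compound 3 to compound 4 (1.40 log units; beyond the scatter) as a large loss on this read-out. Dimethylamino also stands far from the other two groups, with a 30-fold higher number from compound 2 to compound 4 (1.48 log units; beyond the scatter) for benzylamino and a 39-fold higher number from compound 1 to compound 4 (1.60 log units; beyond the scatter) for 2-chlorophenyl as the replaced group. Benzylamino, 2-chlorophenyl and cyclopentyl(methyl)amino differ considerably in structure yet remain within the scatter of one another, so only dimethylamino breaks from the group.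

Nothing measured here gives a reason for this jump.

Going by these compounds, it remains open whether an ethyl or isopropyl group on that nitrogen would restore the lower numbers, and whether a ring is needed at all or an open butyl chain would serve as well as cyclopentyl.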